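Nitro for Bromo: Estimating the Cytotoxicity of Compound 4

A few compounds are considered here, and "the series" means these few. Any claim that something is new, unique, unknown or untested is made for them only; others in the source may bear on it.

Of the compounds shown here, three sharing one core have been measured in a functional assay on MKN-45 cells (Homo sapiens) for cytotoxicity, read by MTT assay, with a stated time of 72 h; a higher number here means a weaker inhibitor, a lower number a stronger inhibitor. Compound 2 `COc1cc2c(Oc3ccc(NC(=O)c4nn(-c5ccc(F)cc5)c(=O)c5ccccc45)cc3F)ccnc2cc1OCCCN1CCC(C)CC1` gives 130 nM, compound 3 `COc1cc2c(Oc3ccc(NC(=O)c4nn(-c5ccc(Br)cc5)c(=O)c5ccccc45)cc3F)ccnc2cc1OCCCN1CCC(C)CC1` gives 330 nM, and compound 1 `COc1cc2c(Oc3ccc(NC(=O)c4nn(-c5ccc([N+](=O)[O-])cc5)c(=O)c5ccccc45)cc3F)ccnc2cc1OCCCN1CCCCC1` gives 1140 nM. Compound 3 therefore stands second highest of the three numbers, with compound 2 nearest to it and compound 1 furthest away.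

For the measured compounds named here, the single measured step that bears on the new compound is a 2.5-fold higher number from compound 2 to compound 3 (0.40 log units; beyond the scatter), a modest weakening that goes beyond the usual scatter.

Compound 4 `COc1cc2c(Oc3ccc(NC(=O)c4nn(-c5ccc([N+](=O)[O-])cc5)c(=O)c5ccccc45)cc3F)ccnc2cc1OCCCN1CCC(C)CC1` differs from compound 3 by nitro in place of bromo on an aromatic carbon. Going by the values given here, no measured pair isolates exactly this change on the same core. Compound 1 also carries a 4-nitrophenyl group, and its value of 1140 nM is the highest number in the set, though it differs from compound 4 elsewhere as well, so its bearing is only indirect.

Taking the weakening seen from fluoro to bromo together with the high number of compound 1, the step of a 2.7-fold higher number from compound 3 to compound 4 (0.44 log units; beyond the scatter) is expected to continue in the weakening direction. Compound 4 is estimated at 900 nM, within a range from 400 nM to 2500 nM, with a numerical result rather than a limit expected.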

Compound 4, half-maximal inhibitory concentration: 1150 nM
Compound 4: middle estimate off by 1.3-fold (0.11 log units), on the low side; measured number inside the range.
By their numbers in this assay, from the lowest: compound 2; then compound 3; then compounds 1 and 4 (each within the scatter of the next).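

For the compounds shown here, compound 4 gives the first direct reading of nitro at this position on the shared core: in this assay, the change from 4-bromophenyl to 4-nitrophenyl gives a 3.5-fold higher number from compound 3 to compound 4 (0.54 log units; beyond the scatter) and the replacement of fluoro by nitro gives an 8.8-fold higher number from compound 2 to compound 4 (0.95 log units; beyond the scatter) on the same core. Among these three compounds, the numbers therefore rise in the order fluoro, bromo, nitro, with every step beyond the scatter. The methyl on the saturated ring carbon gives a 1.0-fold higher number from compound 1 to compound 4 (0.00 log units; within the scatter) with the 4-nitrophenyl group in place, so compound 1 and compound 4 can be read as equal in this assay, and the high number of compound 1 is not specific to its unmethylated ring.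

No measurement shown here explains the order of the three groups. On these data alone, it remains open whether an amine, a nitrile or a methoxy group at this position would fit that order, and whether methyl on the saturated ring would also leave the number unmoved with fluoro or bromo on the aromatic ring.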